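A few compounds are considered here, and "the series" means these few. Any claim that something is new, unique, unknown or untested is made for them only; others in the source may bear on it.

Compound 3, `NC(N)=NC(=O)c1nc(Cl)c(NC2CCCCC2)nc1N`, is the point of departure. Among the measured compounds shown here, in an assay for inhibition of acid-sensing ion channel 3 (Homo sapiens), read by patch clamp, tested at 20 uM (on this read-out lower numbers stand for less inhibition and higher numbers for more inhibition at the one concentration tested (going by the name of the read-out)), compound 3 gives 92%, which is the largest of the three numbers so far, though it cannot be set apart from compound 1, `CCCNc1nc(N)c(C(=O)N=C(N)N)nc1Cl`, which gives 91% in this assay, since a number 1 percentage points higher from compound 1 to compound 3 (within the scatter). Compound 2, `NC(N)=NC(=O)c1nc(Cl)c(NC2CC2)nc1N`, gives 78% in this assay, and the move from it to compound 3 is a number 14 percentage points higher from compound 2 to compound 3 (beyond the scatter), while the move from compound 1 to compound 2 is a number 13 percentage points lower from compound 1 to compound 2 (beyond the scatter).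

Compound 4, `CCCN(C)c1nc(N)c(C(=O)N=C(N)N)nc1Cl`, has not yet been measured. Its change from compound 3 is methyl(propyl)amino in place of cyclohexylamino on an aromatic carbon. For the measured compounds named here, the step from compound 1 to compound 3 bears on it most closely, since it exchanges propyl for cyclohexyl on the same nitrogen and stays within the scatter; no measured step tells what adding a methyl to that nitrogen does, so the second part of the change rests on nothing measured. Compound 4 is therefore expected to stay near the number for compound 3 or fall somewhat below it, the step being estimated as a number 12 percentage points lower from compound 3 to compound 4 (beyond the scatter). The value of compound 4 in this assay is estimated at 80%, with a range from 55% to 95%.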

Compound 4, a percentage reported as inhibition, at one concentration (the size of the read-out at that concentration, not a potency): 91%
The estimate for compound 4 lay 11 percentage points below the measured number; measured number inside the range.
By their numbers in this assay, from the lowest: compound 2; then compounds 1, 4 and 3 (each within the scatter of the next).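

In this assay, a methyl on the nitrogen of compound 1 gives no change at the digits printed from compound 1 to compound 4 (within the scatter), so on this aromatic carbon the read-out does not depend on that nitrogen keeping its hydrogen. The exchange of cyclohexylamino for methyl(propyl)amino gives a number 1 percentage points lower from compound 3 to compound 4 (within the scatter), so a group with no ring and no hydrogen-bond donor sits within the scatter of one that has both, while a number 13 percentage points higher from compound 2 to compound 4 (beyond the scatter) leaves compound 2, with its cyclopropylamino group, as the only one of the four set apart from the others. Nothing available explains these steps, and no measurement gives a cause for them.

From the compounds shown here alone, these are readings at one concentration and not potencies, so whether compound 1, compound 3 and compound 4 would separate at lower concentrations stays open. Also open is whether a morpholine ring or a chain ending in a carboxylic acid at this position would give a number level with those of the groups shown, and whether a second cyclopropyl-sized group would follow compound 2 or the other three.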